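The source may report more compounds than this note shows. Statements on the series, on what has been measured and on what is new or still open speak of the compounds shown alone.

Measured compounds:
compound 1, `N#Cc1c(Cl)nc(SCC(=O)Nn2c(COc3ccc(Cl)cc3Cl)nc3ccccc3c2=O)nc1-c1ccc(O)cc1`: 73.7%
compound 2, `N#Cc1c(Nc2ccccc2)nc(SCC(=O)Nn2c(COc3ccc(Cl)cc3Cl)nc3ccccc3c2=O)nc1-c1ccc(O)cc1`: 91.2%

In a functional assay on the whole organism (strain albino) for inhibition, with Rattus norvegicus as the target, read by paw edema, with stated times of 1 h and 3 h, at a dose of 100 mg/kg by the oral route (a lower number here means a weaker effect, a higher number a stronger effect of the compound at the dose given), compound 1 gives 73.7%, and compound 2 gives 91.2%. For the measured compounds named here, compound 2 stands highest of the two numbers; its only neighbour is compound 1, and the one measured step is a number 17.5 percentage points higher from compound 1 to compound 2 (beyond the scatter), which concerns the group on the aromatic carbon of the shared core.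

Compound 3, `N#Cc1c(Nc2ccc(O)cc2)nc(SCC(=O)Nn2c(COc3ccc(Cl)cc3Cl)nc3ccccc3c2=O)nc1-c1ccc(O)cc1`, differs from compound 2 at another site: hydroxy in place of hydrogen on an aromatic carbon. This change lies on the anilino ring, not on the core, so the step of a number 17.5 percentage points higher from compound 1 to compound 2 (beyond the scatter) bears on it only indirectly: it shows that the region around the anilino group tolerates variation, but it does not tell how a hydroxy at this ring behaves. With nothing else to go on, the writer expects compound 3 to sit close to compound 2, with a step of a number 3.2 percentage points lower from compound 2 to compound 3 (within the scatter) that is expected to stay within the scatter of this assay. His estimate for compound 3 in this assay is 88%, with a range from 75% to 97%.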

Compound 3, a percentage reported as inhibition, in the whole organism at one dose (the size of the read-out at that dose, not a potency): 86.8%
Compound 3: middle estimate off by 1.2 percentage points, on the high side; the range from low to high includes it.
By their numbers in this assay, from the lowest: compound 1; then compounds 3 and 2 (each within the scatter of the next).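

In this assay, a step of a number 4.4 percentage points lower from compound 2 to compound 3 (within the scatter) shows that hydroxy in place of hydrogen on the anilino ring, para to a large group, cannot be told apart from the unsubstituted ring at the dose given. The advantage over chloro also survives this change, with a step of a number 13.1 percentage points higher from compound 1 to compound 3 (beyond the scatter), so the effect seen earlier with anilino is not limited to the unsubstituted phenyl ring. The data include no measured property that bears on this result.

The compounds shown leave open whether other groups at this place on the ring, such as methoxy, chloro or a carboxylic acid, would read the same way, and whether a hydroxy elsewhere on the ring would do so too. They also leave open whether a non-aromatic amine such as morpholine, in place of chloro on the shared core, would match the anilino compounds, and, with every value taken at a single dose, how these compounds compare in potency.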